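The source may hold more compounds than are shown below. What is called first, only, known or untested is meant among the compounds shown, and "the series" means these compounds.

Going by the values given here, in a functional assay on the whole organism for positive allosteric modulation, with Mus musculus as the target (a lower number here means that less compound is needed, a higher number that more compound is needed for the effect), three compounds have values so far. Compound 1 `CCC(=O)N(c1ccc(OC)c(OC)c1)C1CCCC1N(C)C` gives 9 mg/kg. Compound 2 `CCC(=O)N(c1ccc(C(C)=O)cc1)C1CCCC1N(C)C` gives > 50 mg/kg, which is a limit of the assay and not a number. Compound 3 `CCNC1CCCC1N(C(=O)CC)c1ccc(Cl)c(Cl)c1` gives 0.2 mg/kg, the lower of the two actual numbers. The gap between compound 3 and compound 1 lies beyond the scatter.

Compound 4 `C=CCN(C)C1CCCC1N(C(=O)CC)c1ccc(Cl)c(Cl)c1` keeps the rest of compound 3 and carries allyl(methyl)amino in place of ethylamino on a saturated ring carbon. Among the compounds with values here, no measured pair in this assay isolates this change, and compound 1 and compound 2 each differ from compound 3 in more than one place. The only close reference is therefore compound 3 at 0.2 mg/kg, and from a number that low, a rise seems more likely than a further fall. The expected result is a moderate move towards a higher number, estimated as a 4.0-fold higher number from compound 3 to compound 4 (0.60 log units; beyond the scatter). For compound 4 the estimated value is 0.8 mg/kg, with an expected range of 0.15 mg/kg to 5 mg/kg.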

Compound 4, dose for half-maximal effect: 0.2 mg/kg
The estimate for compound 4 lay 4.0-fold (0.60 log units) above the measured number, and the stated range covers the measured number.
By their numbers in this assay, from the lowest: compounds 3 and 4 (each within the scatter of the next); then compound 1. At a limit, above all of these: compound 2.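

In this assay, going by these compounds alone, allyl(methyl)amino in place of ethylamino on a saturated ring carbon gives no change at the digits printed from compound 3 to compound 4 (within the scatter), the first reading of this position with the rest of compound 3 held constant. Compound 4 gives 0.2 mg/kg with 5 heavy atoms in the group instead of 3 and with 0 hydrogen-bond donors instead of 1, so neither the hydrogen-bond donor of ethylamino nor the smaller size of that group is required for a number at this level. Nothing at hand accounts for the flat step.

Open, from the compounds shown here alone, is whether a pyrrolidine ring or a longer chain such as n-butyl in this place would keep the number. Also open, going by these compounds, is whether the same exchange holds with the aromatic substituents of compound 1.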